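The compounds below may be only part of what the source reports. "The series", "measured", "known", "first", "only" and "open" are said of these compounds alone.

Measured compounds:
- compound 1 `Cc1ccc2c(=O)c(CSC(=S)N(C(C)C)C(C)C)coc2c1`, in a functional assay on MDA-MB-435S cells (Homo sapiens) for antiproliferative activity, read by MTT assay, with a stated time of 72 h (a lower number here means a stronger inhibitor, a higher number a weaker inhibitor), compound 1 gives 240 nM
- compound 2 `O=c1c(SC(=S)N2CCCCC2)coc2ccccc12`, compound 2 gives 17400 nM
- compound 3 `O=c1c(SC(=S)N2CCCC2)coc2ccccc12`, compound 3 gives 1900 nM

Compound 2 stands highest of the three numbers. Its nearest neighbour is compound 3, reached by a 9.2-fold lower number from compound 2 to compound 3 (0.96 log units; beyond the scatter); compound 1 lies furthest, its value being far lower than that of compound 2, though the two differ in more than one place.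

Compound 4 `O=c1c(SC(=S)N2CCCCC2)coc2ccc(Cl)cc12` differs from compound 2 by chloro in place of hydrogen on an aromatic carbon. Within the data shown here, no measured step touches this ring position: the only single-point step in the set, a 9.2-fold lower number from compound 2 to compound 3 (0.96 log units; beyond the scatter), concerns the amine on the thiocarbonyl carbon and says nothing about a substituent here. The expectation for compound 4 is therefore a step within the scatter, a 1.5-fold lower number from compound 2 to compound 4 (0.16 log units; within the scatter), with a wide range. Compound 4 is estimated at 12000 nM, between 4000 nM and 35000 nM.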

Compound 4, half-maximal inhibitory concentration: 13300 nM
For compound 4 the middle estimate is 1.1-fold (0.04 log units) below the measured one, within the range that was stated.
By their numbers in this assay, from the lowest: compound 1; then compound 3; then compounds 4 and 2 (each within the scatter of the next).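

Chloro in place of hydrogen on an aromatic carbon of the shared core gives a 1.3-fold lower number from compound 2 to compound 4 (0.12 log units; within the scatter) in this assay. Among these compounds, this is the first reading at this ring position, and here the two compounds cannot be told apart, whereas the earlier step at the amine lay beyond the scatter. Nothing available explains this result.

On these data alone, whether a methoxy group, a nitrile or a carboxylic acid on this carbon would read the same remains open. Also open, as far as these compounds go, is whether chloro would read the same with the pyrrolidin-1-yl group of compound 3.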